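A Nitrophenyl Variant of the Stronger Bromophenyl Amide

The compounds below may be only part of what the source reports. "The series", "measured", "known", "first", "only" and "open" are said of these compounds alone.

Going by the values given here, compound 2 `O=C(COc1ccc2c(=O)ccoc2c1)Nc1cccc(NC(=O)c2ccc(Br)cc2)c1` gives 49 nM in an assay on isolated protein for inhibition of Rho-associated protein kinase 2 (Homo sapiens), read by scintillation counting, radiometric assay and 33P incorporation, with a stated time of 40 min, in the presence of a further agent that is not named here (a higher number here means a weaker inhibitor, a lower number a stronger inhibitor), the lower of the two numbers measured so far. Compound 1 `Cc1coc2cc(OCC(=O)Nc3cccc(NC(=O)c4ccc(N(C)C)cc4)c3)ccc2c1=O` gives 2150 nM in this assay, a gap beyond the usual scatter. Compound 3 `O=C(COc1ccc2c(=O)ccoc2c1)Nc1cccc(NC(=O)c2cccc([N+](=O)[O-])c2)c1` differs from compound 2 by 3-nitrophenyl in place of 4-bromophenyl on a carbonyl carbon. Among the compounds with values here, no measured pair shows this particular change, so its effect is unknown here. A modest weakening is expected, with the step of a 2.4-fold higher number from compound 2 to compound 3 (0.39 log units; beyond the scatter) thought to lie near the edge of the scatter. Compound 3 is therefore estimated at 120 nM in this assay, within a range from 30 nM to 500 nM.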

Compound 3, half-maximal inhibitory concentration: 41 nM
For compound 3 the middle estimate is 2.9-fold (0.47 log units) above the measured one, and the stated range covers the measured number.
By their numbers in this assay, from the lowest: compounds 3 and 2 (each within the scatter of the next); then compound 1.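

In this assay, going by these compounds alone, 3-nitrophenyl in place of 4-bromophenyl on a carbonyl carbon gives a 1.2-fold lower number from compound 2 to compound 3 (0.08 log units; within the scatter), the first single-place step at this position. The position thus tolerates this exchange, although the entering group carries hydrogen-bond acceptors and the leaving group none. Nothing measured here accounts for the two groups reading alike.

Still open, on these data alone, is how a carboxylic acid or a primary amine would read on this phenyl ring. Compound 1 differs from compound 2 in more than one place, so its higher number cannot be assigned to either.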